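The source may hold more compounds than are shown below. What is called first, only, known or untested is meant among the compounds shown, and "the series" means these compounds.

Two compounds of this series carry measured numbers in an assay on isolated protein for binding affinity to 5-hydroxytryptamine receptor 5A (Homo sapiens); on this read-out lower numbers stand for stronger inhibition and higher numbers for weaker inhibition. Compound 1, `CCCN(CCC)Cc1ccc(Cl)c(-c2ccccc2OC)c1`, reached only a limit of the assay: in this assay compound 1 gives > 10000 nM. Among the compounds with values here, compound 2, `COc1ccccc1-c1cc(C2CCNC2)ccc1Cl`, gives in this assay 970 nM, and this is the only actual number among the two values shown. The other value, that of compound 1, is a limit: the limit of > 10000 nM in this assay, at which 1 of the 2 values shown sits. Compound 3, `COc1ccccc1-c1cc(C2CCN(C)C2)ccc1Cl`, has not yet been measured. It differs from compound 2 in one place: methyl in place of hydrogen on an amine nitrogen in a ring. Within the data shown here, no measured pair shows this change, so its effect in this assay cannot be read from the numbers at hand. With nothing pointing in either direction, compound 3 is expected to stay close to compound 2, a step of a 1.3-fold lower number from compound 2 to compound 3 (0.11 log units; within the scatter) that is expected to remain within the usual scatter. The estimate for compound 3 in this assay is 750 nM, within an expected range from 200 nM to 3000 nM.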

Compound 3, inhibition constant: 1000 nM
Beside the measured number, compound 3's estimate is 1.3-fold (0.12 log units) below it; low and high end bracket the measured number.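

In this assay, methyl in place of hydrogen on an amine nitrogen in a ring gives a 1.0-fold higher number from compound 2 to compound 3 (0.01 log units; within the scatter). Within the data shown here, this is the first measured pair to isolate a single change, and it shows that, at this position on the shared core, pyrrolidin-3-yl and 1-methylpyrrolidin-3-yl cannot be told apart in this read-out, so a hydrogen on this nitrogen is not needed to keep the value seen for compound 2. Compound 1 still offers a limit rather than a number, and no step connects it to this pair: the limit of > 10000 nM in this assay, at which 1 of the 3 values shown sits.

The compounds shown leave open whether a larger group on this same nitrogen, such as ethyl, a longer chain or benzyl, would leave the number in this assay as undisturbed as methyl does. They also leave open what an amide or a carboxylic acid would do in place of the ring amine, since this single pair speaks only for hydrogen and methyl on this one nitrogen.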